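The source may hold more compounds than are shown below. What is called first, only, known or untested is meant among the compounds shown, and "the series" means these compounds.

Measured in an ADME assay on MDBK cells (Bos taurus) for cytotoxicity, read by MTT assay, with a stated time of 96 h; a lower number here means that less compound is tolerated, a higher number that more compound is tolerated:
compound 1 `Cc1ccc(/N=N/c2ccc(NCCCN(C)C)cc2)cc1`, whose value > 100000 nM is a limit of the assay, not a number.
compound 2 `CN(C)CCCNc1ccc(/N=N/c2ccccc2)cc1`, 58000 nM.
compound 3 `CN(C)CCCN(/N=N/c1ccccc1)c1ccccc1`, 95000 nM.

From compound 2 to compound 1 the change is methyl in place of hydrogen on an aromatic carbon. The number moves by an at least 1.7-fold higher number from compound 2 to compound 1 (0.23 log units; that floor lies within the scatter), and the result for compound 1 sits at the limit of > 100000 nM in this assay, at which 1 of the 3 values shown sits, so the true size of that step is open at the top. Compound 3 and compound 2 hold the same atoms joined differently; the difference between the two cores is not broken down here. Compound 4 `Cc1ccc(/N=N/N(CCCN(C)C)c2ccccc2)cc1` is not yet measured. From compound 3 to compound 4 the change is methyl in place of hydrogen on an aromatic carbon, the same change at the same kind of place as before.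

Resting on an at least 1.7-fold higher number from compound 2 to compound 1 (0.23 log units; that floor lies within the scatter) and on the value of compound 3, 95000 nM, the step from compound 3 to compound 4 in this assay is expected to be a 1.6-fold higher number from compound 3 to compound 4 (0.20 log units; within the scatter). Compound 4 is therefore estimated at 150000 nM, with a likely range from 70000 nM to 300000 nM. A result reported only as a limit would not be surprising.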

Compound 4, half-maximal cytotoxic concentration: > 100000 nM
Compound 4: a limit, no number; the forecaster's own chance of this, stated with the estimate: 60%; the middle value lies beyond the limit too.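

In this assay compound 4 gives > 100000 nM, which is a limit of the assay and not a number. The change from phenyl to 4-methylphenyl gives an at least 1.0-fold higher number from compound 3 to compound 4 (0.02 log units; that floor lies within the scatter), and the two cores can be compared only through such floors: the same change on two cores in this assay, an at least 1.7-fold higher number (0.23 log units; that floor lies within the scatter) from compound 2 to compound 1 and an at least 1.0-fold higher number (0.02 log units; that floor lies within the scatter) from compound 3 to compound 4; the limit leaves it open whether they differ. The results show that methyl on this aromatic carbon leaves both methyl compounds at the limit, but they do not show how large the step is on either core or whether it carries over unchanged: the limit of > 100000 nM in this assay, at which 2 of the 4 values shown sit.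

The compounds shown leave open how either core responds to a group other than methyl at that place, such as chlorine, methoxy or a carboxylic acid. Among these compounds, they also leave open what a longer chain would do in place of the one carrying the dimethylamino group.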